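This account rests on a few compounds, and the source may have more. Where it says the series, first, only, none or still open, it means among the compounds named here.

Compound 3 `CN(C)C1(Cc2ccccc2)CCN(c2cc(C(F)(F)F)ccc2CNC(=O)Nc2cccc3c(=O)[nH]ccc23)CC1` gives the highest number of the three compounds in an assay on CHO cells for displacement of a labelled ligand from transient receptor potential cation channel subfamily V member 1 (Homo sapiens), read by scintillation counting, with a stated time of 60 min (on this read-out higher numbers stand for weaker inhibition and lower numbers for stronger inhibition), at 111 nM. Compound 1 `CN(C)C1(Cc2ccccc2)CCN(c2cc(C(F)(F)F)ccc2CNC(=O)Nc2cccc3ccc(O)cc23)CC1` gives 0.46 nM and compound 2 `CN(C)C1(Cc2ccccc2)CCN(c2cc(C(F)(F)F)ccc2CNC(=O)Nc2cccc3c2CC(O)CC3)CC1` gives 0.95 nM, so the step of a 240-fold higher number from compound 1 to compound 3 (2.38 log units; beyond the scatter) and the step of a 120-fold higher number from compound 2 to compound 3 (2.07 log units; beyond the scatter) both show that exchanging the group on the amide-type nitrogen moves this assay by a large amount. Compound 4 `CN(C)C1(Cc2ccccc2)CCN(c2cc(C(F)(F)F)ccc2CNC(=O)Nc2ccc3ccncc3c2)CC1` differs from compound 3 in the same place: a group of 10 heavy atoms (9 carbon, 1 nitrogen; one six-membered aromatic ring of carbon only, one six-membered aromatic ring with 1 hetero atom) in place of a group of 11 heavy atoms (9 carbon, 1 nitrogen, 1 oxygen; one six-membered aromatic ring of carbon only, one six-membered aromatic ring with 1 hetero atom), on an amide-type nitrogen. The measured steps show only that this region is sensitive, not where isoquinolin-7-yl will land. Because the steps of a 240-fold higher number from compound 1 to compound 3 (2.38 log units; beyond the scatter) and a 120-fold higher number from compound 2 to compound 3 (2.07 log units; beyond the scatter) were large, a large step downward is expected here, a 22-fold lower number from compound 3 to compound 4 (1.35 log units; beyond the scatter). For compound 4 the estimate in this assay is 5 nM, with a range from 0.8 nM to 40 nM.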

Compound 4, inhibition constant: 7.33 nM
The estimate for compound 4 lay 1.5-fold (0.17 log units) below the measured number; low and high end bracket the measured number.
By their numbers in this assay, from the lowest: compound 1; then compound 2; then compound 4; then compound 3.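

Isoquinolin-7-yl on the amide-type nitrogen has 0 hydrogen-bond donors, yet in this assay it does far better than the group it replaces, which has 1 (a 15-fold lower number from compound 3 to compound 4 (1.18 log units; beyond the scatter)), so a donor in this group does not by itself give a low number. It still trails 3-hydroxy-1,2,3,4-tetrahydronaphthalen-5-yl (a 7.7-fold higher number from compound 2 to compound 4 (0.89 log units; beyond the scatter)) and 7-hydroxynaphthalen-1-yl (a 16-fold higher number from compound 1 to compound 4 (1.20 log units; beyond the scatter)). No evidence at hand accounts for these steps. Still open, going by these compounds, is how an amine or a hydroxyl group added to isoquinolin-7-yl would change the number.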